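A few compounds are considered here, and "the series" means these few. Any claim that something is new, unique, unknown or untested is made for them only; others in the source may bear on it.

Measured so far:
- Compound 1 `COc1cc2c(Oc3ccc(NC(=O)c4nn(-c5ccccc5OC(F)(F)F)c(=O)cc4C)cc3F)ccnc2cc1OCCCN1CCCC1`: 180 nM
- Compound 2 `COc1cc2c(Oc3ccc(NC(=O)c4nn(-c5cccc(F)c5)c(=O)cc4C)cc3F)ccnc2cc1OCCCN1CCCC1`: 250 nM

Both compounds share one large core and differ only in the ring attached to an aromatic nitrogen. In a functional assay on HT-29 cells (Homo sapiens) for inhibition, read by MTT assay, with a stated time of 72 h (a higher number here means a weaker inhibitor, a lower number a stronger inhibitor), compound 1 gives 180 nM, and in this assay compound 2 gives 250 nM. Going by the values given here, compound 2 has the highest of the two numbers, but its one neighbour is compound 1, and the change a 1.4-fold higher number from compound 1 to compound 2 (0.14 log units; within the scatter) is within the scatter, so the two cannot be told apart on these numbers.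

Compound 3 `COc1cc2c(Oc3ccc(NC(=O)c4nn(-c5ccc(Cl)cc5)c(=O)cc4C)cc3F)ccnc2cc1OCCCN1CCCC1` is the next variation on the same ring. The change from compound 2 is 4-chlorophenyl in place of 3-fluorophenyl on an aromatic nitrogen. Among the compounds with values here, the only step that bears on it is the one from compound 1 to compound 2, which also swapped one substituted phenyl ring for another at this position, and that step was a 1.4-fold higher number from compound 1 to compound 2 (0.14 log units; within the scatter). On that evidence a change within the scatter is expected again, with no firm direction. The estimated step is a 1.1-fold lower number from compound 2 to compound 3 (0.06 log units; within the scatter). Compound 3 is therefore expected to give about 220 nM in this assay, with a likely range from 90 nM to 550 nM.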

Compound 3, half-maximal inhibitory concentration: 260 nM
The estimate for compound 3 lay 1.2-fold (0.07 log units) below the measured number; measured number inside the range.
By their numbers in this assay, from the lowest: compounds 1, 2 and 3 (each within the scatter of the next).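

In this assay, replacing 3-fluorophenyl with 4-chlorophenyl gives a 1.0-fold higher number from compound 2 to compound 3 (0.02 log units; within the scatter), and replacing the 2-(trifluoromethoxy)phenyl ring of compound 1 with the same 4-chlorophenyl ring gives a 1.4-fold higher number from compound 1 to compound 3 (0.16 log units; within the scatter). Compound 3 adds a second pair of comparisons to the single one available before: the substituent on the phenyl ring now differs in both identity and location, yet all three compounds remain within the scatter of one another, so this assay separates none of these three rings. Nothing beyond these cell numbers bears on why the three compounds cannot be separated, so the result stands as an observation without an explanation.

As far as these compounds go, all three groups at this position are phenyl rings carrying a single neutral substituent, so it remains open whether the number would hold with a carboxylic acid or an aminomethyl group on that ring, or with a small methyl group on the aromatic nitrogen in place of the ring. Each comparison also uses the same shared core, which leaves open whether the same flat picture would appear with any other core.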